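Inverting two ring stereocentres of compound 2

A few compounds are considered here, and "the series" means these few. Any claim that something is new, unique, unknown or untested is made for them only; others in the source may bear on it.

In a functional assay on HepG2 cells (Homo sapiens) for antiproliferative activity (a lower number here means a stronger inhibitor, a higher number a weaker inhibitor), compound 2 (`CC[C@H](C)[C@H]1C(=O)N[C@H](Cc2ccc(O)c(Br)c2)C(=O)N[C@@H](C(C)(C)O)C(=O)O[C@H](c2ccccc2)[C@H](C)/C=C/C=C(\C)[C@H](OC)C[C@@H]2O[C@@]2(C)C(=O)N1C`) gives 2.98 nM as its number, which lies within the usual scatter of compound 1 (`CC[C@H](C)[C@H]1C(=O)N[C@H](Cc2ccc(O)c(Br)c2)C(=O)N[C@@H](C(C)(C)O)C(=O)O[C@H](c2ccccc2)[C@H](C)/C=C/C=C(\C)[C@H](OC)C/C=C(\C)C(=O)N1C`) at 5.21 nM in the same test. Compound 3 (`CC[C@H](C)[C@H]1C(=O)N[C@H](Cc2ccc(O)c(Br)c2)C(=O)N[C@@H](C(C)C)C(=O)O[C@H](c2ccccc2)[C@H](C)/C=C/C=C(\C)[C@H](OC)C[C@@H]2O[C@@]2(C)C(=O)N1C`) gives 6.84 nM and stands apart from its partner, the measured step being a 2.3-fold higher number from compound 2 to compound 3 (0.36 log units; beyond the scatter) with hydrogen in place of hydroxy on a saturated chain carbon.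

Compound 4 (`CC[C@H](C)[C@H]1C(=O)N[C@H](Cc2ccc(O)c(Br)c2)C(=O)N[C@@H](C(C)(C)O)C(=O)O[C@H](c2ccccc2)[C@H](C)/C=C/C=C(\C)[C@H](OC)C[C@H]2O[C@]2(C)C(=O)N1C`) departs from compound 2 in one respect only (the two compounds have the same atoms and bonds and differ only in configuration as drawn: 2 of 11 stereo elements differ; a stereocentre at a saturated ring carbon is drawn S in compound 2 and R in compound 4; a stereocentre at a saturated ring carbon is drawn R in compound 2 and S in compound 4) and so keeps the same atoms and bonds. Within the data shown here, no measured step inverts a stereocentre, so the data hold no direct precedent. Among the measured compounds shown here, the one measured step lies at another place and was modest, and compound 1, which lacks both stereocentres, still gives 5.21 nM in this series. A large loss is therefore not expected, though some shift toward a higher number is. The estimated change is a 4.0-fold higher number from compound 2 to compound 4 (0.60 log units; beyond the scatter) in this assay with wide uncertainty. For compound 4 the estimated value is 12 nM with an expected range from 3 nM to 60 nM in all.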

Compound 4, half-maximal inhibitory concentration: > 200 nM
Compound 4: only a limit was reported (the forecaster's own chance of this, stated with the estimate: 3%); at least 16-fold (1.22 log units) between middle value and limit.
By their numbers in this assay, from the lowest: compounds 2, 1 and 3 (each within the scatter of the next, the first and the last beyond it). At a limit, above all of these: compound 4.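

In this assay compound 4 gives only a limit, > 200 nM, and not a number. Even so, the step of an at least 67-fold higher number from compound 2 to compound 4 (1.82 log units; beyond the scatter) is large and is the only change of configuration among the compounds shown, and it far outweighs the modest step of a 2.3-fold higher number from compound 2 to compound 3 (0.36 log units; beyond the scatter), where hydrogen replaces hydroxy on a saturated chain carbon. This shows that activity in this series depends strongly on the configuration at these two saturated ring carbons, and the loss can be placed there alone because of one fact: the fact that compounds 2 and 4 differ only in the configuration as drawn

On these data alone, since both stereocentres change together, what each inversion contributes alone remains open, as does how far compound 4 lies past its limit. As far as these compounds go, it is also open whether an amine on either of these saturated ring carbons would give a different outcome in the inverted configuration.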